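Pyrazolyl enone series: trimethoxy to dimethoxy step

This account rests on a few compounds, and the source may have more. Where it says the series, first, only, none or still open, it means among the compounds named here.

Measured compounds:
compound 1 `COc1cc(-c2cc(/C=C/C(=O)c3ccc(N)cc3)[nH]n2)cc(OC)c1OC` 8700 nM
compound 2 `COc1ccc(-c2cc(/C=C/C(=O)c3ccc(N)cc3)[nH]n2)cc1OC` 32000 nM
compound 3 `COc1cc(C(=O)/C=C/c2cc(-c3cc(OC)c(OC)c(OC)c3)n[nH]2)cc(OC)c1OC` 5740 nM

All three were run in a functional assay on HOP-62 cells (Homo sapiens) for inhibition, read by sulforhodamine B assay, with a stated time of 48 h; on this read-out lower numbers stand for higher toxicity in this test and higher numbers for lower toxicity in this test. Compound 3 gives the lowest of the three numbers, but its gap to compound 1 is within the scatter, so no order between those two is claimed; its gap to compound 2 is beyond the scatter.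

Between compound 1 and compound 2 the change is hydrogen in place of methoxy on an aromatic carbon, and it gives a 3.7-fold higher number from compound 1 to compound 2 (0.57 log units; beyond the scatter). Compound 4 `COc1ccc(-c2cc(/C=C/C(=O)c3cc(OC)c(OC)c(OC)c3)[nH]n2)cc1OC` is not yet measured; it differs from compound 3 by hydrogen in place of methoxy on an aromatic carbon, the same change at the same kind of place. How the core of compound 3 differs from the core of compound 1 is not broken down here.

Among the compounds with values here, with only one earlier instance, the expectation for compound 4 rests on compound 1 to compound 2 in this assay giving a 3.7-fold higher number from compound 1 to compound 2 (0.57 log units; beyond the scatter). Compound 4 is expected to show a step of a 3.7-fold higher number from compound 3 to compound 4 (0.56 log units; beyond the scatter), a higher number than compound 3. Compound 4 is estimated at 21000 nM, between 8000 nM and 60000 nM.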

Compound 4, concentration lethal to 50% of the cells: 8850 nM
The estimate for compound 4 lay 2.4-fold (0.38 log units) above the measured number; the range from low to high includes it.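

In this assay, hydrogen in place of methoxy on the core of compound 3 gives a 1.5-fold higher number from compound 3 to compound 4 (0.19 log units; within the scatter), so on this core the change cannot be told apart from no change. Set beside the earlier step on the core of compound 1, the new step does not differ from it: the same change on two cores in this assay, a 3.7-fold higher number (0.57 log units; beyond the scatter) from compound 1 to compound 2 and a 1.5-fold higher number (0.19 log units; within the scatter) from compound 3 to compound 4, 2.4-fold (0.38 log units) apart, within the scatter of two such steps. Within the data shown here, this shows that the two cores give no detectable disagreement, but it does not show that the change has one fixed size across the series or that its size depends on the core, since only two pairs are available and only the first step lies beyond the scatter.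

The compounds shown leave open whether any replacement other than hydrogen, such as a hydroxyl, an ethoxy group or a fluorine atom, would give a step that can be read on either core. They also leave open whether the same change would give a clearer step on a third core carrying a different group, such as a carboxylic acid, in place of the amine of compound 1.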